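Swapping nitro for fluoro: compound 3 to compound 4

The compounds below may be only part of what the source reports. "The series", "measured", "known", "first", "only" and "open" are said of these compounds alone.

Three compounds have been measured in a functional assay on MCF7 cells (Homo sapiens) for antiproliferative activity; a higher number here means a weaker inhibitor of growth, a lower number a stronger inhibitor of growth:
compound 1, `O=C(/C=C/c1cnc(N2CCN(S(=O)(=O)c3ccc4ccccc4c3)CC2)s1)NO`, 700 nM
compound 2, `O=C(/C=C/c1cnc(N2CCN(S(=O)(=O)c3ccccc3)CC2)s1)NO`, 3000 nM
compound 3, `O=C(/C=C/c1cnc(N2CCN(S(=O)(=O)c3ccc([N+](=O)[O-])cc3)CC2)s1)NO`, 5000 nM

Compound 3 stands highest of the three in this assay. The step of a 1.7-fold higher number from compound 2 to compound 3 (0.22 log units; within the scatter) is within the scatter, whereas the step of a 7.1-fold higher number from compound 1 to compound 3 (0.85 log units; beyond the scatter) lies beyond it, as does the step of a 4.3-fold higher number from compound 1 to compound 2 (0.63 log units; beyond the scatter).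

Compound 4, `O=C(/C=C/c1cnc(N2CCN(S(=O)(=O)c3ccc(F)cc3)CC2)s1)NO`, differs from compound 3 in one place: fluoro in place of nitro on an aromatic carbon. Of the measured steps, only a 1.7-fold higher number from compound 2 to compound 3 (0.22 log units; within the scatter) touches this position, and it was within the scatter; the larger steps involve the exchange of naphthalen-2-yl for phenyl or 4-nitrophenyl and do not bear on a change at this aromatic carbon. With the nitro removed and a single fluoro entering, the number for compound 4 is expected to sit close to that of compound 2 and compound 3, with no step beyond the scatter. In this assay the expected step is a 1.4-fold lower number from compound 3 to compound 4 (0.15 log units; within the scatter). Compound 4 is estimated at 3500 nM, within a range from 1500 nM to 8000 nM.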

Compound 4, concentration for 50% growth inhibition: 2500 nM
Compound 4: middle estimate off by 1.4-fold (0.15 log units), on the high side, within the range that was stated.
By their numbers in this assay, from the lowest: compound 1; then compounds 4, 2 and 3 (each within the scatter of the next).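

In this assay the change of nitro to fluoro on the aromatic carbon para to a large group gives a 2.0-fold lower number from compound 3 to compound 4 (0.30 log units; within the scatter) and the change of hydrogen to fluoro at the same carbon gives a 1.2-fold lower number from compound 2 to compound 4 (0.08 log units; within the scatter) so hydrogen, nitro and fluoro are not told apart at this position. The larger difference remains at the sulfonyl sulfur, where 4-fluorophenyl in place of naphthalen-2-yl gives a 3.6-fold higher number from compound 1 to compound 4 (0.55 log units; beyond the scatter) and compound 1 stays apart from all three phenyl compounds. The compounds shown leave open whether an amine or a carboxylic acid on this aromatic carbon would stay within the same narrow band, and whether naphthalen-1-yl on the sulfonyl sulfur would match naphthalen-2-yl. No measured evidence accounts for this pattern.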